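Swapping thiophen-3-yl for thiophen-2-yl on compound 1

A few compounds are considered here, and "the series" means these few. Any claim that something is new, unique, unknown or untested is made for them only; others in the source may bear on it.

In a functional assay on cells (Cancer cell lines, Homo sapiens) for inhibition (on this read-out lower numbers stand for stronger inhibition of growth and higher numbers for weaker inhibition of growth), compound 1 (`Cc1cn2c(/C=N/NC(=N)N)c(-c3ccsc3)nc2s1`) gives 20000 nM and lies within the scatter of both other measured compounds. Compound 2 (`N=C(N)N/N=C/c1c(-c2cc(Cl)sc2Cl)nc2n1CCS2`) differs from compound 1 in more than one place. Compound 2 gives 15100 nM and compound 3 (`N=C(N)N/N=C/c1c(-c2ccsc2)nc2sccn12`) gives 28800 nM as its number.

Compound 4 (`Cc1cn2c(/C=N/NC(=N)N)c(-c3cccs3)nc2s1`) has the same atoms as compound 1, joined differently, with thiophen-2-yl in place of thiophen-3-yl on an aromatic carbon. For the measured compounds named here, no measured pair tests this swap directly. Going by the values given here, the only measured step (a 1.4-fold higher number from compound 1 to compound 3 (0.16 log units; within the scatter)) is a different change, hydrogen in place of methyl on an aromatic carbon, and it stays within the scatter. Among the compounds with values here, it offers only indirect guidance, but nothing measured so far points to a large shift. In this assay no step beyond the scatter is expected, so the estimated step is small (no change at the digits printed from compound 1 to compound 4 (within the scatter)). Compound 4 is therefore estimated at 20000 nM (expected range 10000 nM to 40000 nM).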

Compound 4, concentration for total growth inhibition: 12300 nM
Compound 4: middle estimate off by 1.6-fold (0.21 log units), on the high side; low and high end bracket the measured number.
By their numbers in this assay, from the lowest: compounds 4, 2, 1 and 3 (each within the scatter of the next, the first and the last beyond it).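

For the compounds shown here, at this place on the shared core, on an aromatic carbon of a five-membered aromatic ring with 2 nitrogen, the earlier compounds gave no test of the thiophene itself, and the first such test gives a 1.6-fold lower number from compound 1 to compound 4 (0.21 log units; within the scatter) in this assay. Joining the ring as thiophen-2-yl or as thiophen-3-yl therefore makes no difference beyond the scatter in this read-out, and this adds a second one-place change that stays within it, at a different place from the methyl-to-hydrogen step. No supporting data offer any explanation for how closely the two compounds agree.

From the compounds shown here alone, it remains open whether a larger change at this place, such as a phenyl ring, an amine or a carboxylic acid in place of the thiophene, would shift growth inhibition beyond the scatter. Going by these compounds, it also remains open whether the thiophene swap would read the same on the core without the methyl group.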